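A few compounds are considered here, and "the series" means these few. Any claim that something is new, unique, unknown or untested is made for them only; others in the source may bear on it.

Compound 1 `Clc1cccc(Cl)c1Nc1nc2c(Nc3ccccc3)ncnc2s1` is the starting point of this small set. In a functional assay on HEK293 cells for antagonist activity at transient receptor potential cation channel subfamily V member 1 (Homo sapiens), read by calcium flux (on this read-out higher numbers stand for weaker inhibition and lower numbers for stronger inhibition), compound 1 gives 176 nM. Compound 2 `Cc1ccc(Nc2ncnc3sc(Nc4c(Cl)cccc4Cl)nc23)cc1` differs from it by methyl in place of hydrogen on an aromatic carbon, and that change brought a 5.3-fold lower number from compound 1 to compound 2 (0.73 log units; beyond the scatter); in this assay compound 2 gives 33 nM. Compound 3 `FC(F)(F)c1ccc(Nc2ncnc3sc(Nc4c(Cl)cccc4Cl)nc23)cc1Cl` is built on a different pattern, and the difference between the two cores is not broken down here. In this assay compound 3 gives 21 nM, which sits within the scatter of compound 2 and beyond it from compound 1.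

Compound 4 `Cc1nc(Nc2ccc(C(F)(F)F)c(Cl)c2)c2nc(Nc3c(Cl)cccc3Cl)sc2n1` has not yet been measured. It differs from compound 3 by methyl in place of hydrogen on an aromatic carbon. For the measured compounds named here, this is the same kind of change as the one from compound 1 to compound 2, but not the same: there the methyl entered a six-membered aromatic ring of carbon only, para to a large group, whereas here it enters a six-membered aromatic ring with two nitrogen, part of a fused system, between two ring nitrogen atoms. Because a 5.3-fold lower number from compound 1 to compound 2 (0.73 log units; beyond the scatter) came from a methyl at another place, a smaller step is expected here, a 1.4-fold lower number from compound 3 to compound 4 (0.15 log units; within the scatter). Compound 4 is estimated at 15 nM, within 5 nM to 60 nM.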

Compound 4, half-maximal inhibitory concentration: 3 nM
The estimate for compound 4 lay 5.0-fold (0.70 log units) above the measured number; the measured number lies below the stated range.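

The methyl in place of hydrogen on an aromatic carbon brought a 7.0-fold lower number from compound 3 to compound 4 (0.85 log units; beyond the scatter) in this assay. Set beside the earlier methyl step, the size of the change carried over from one core to the other, even though the methyl entered a different ring in each case: the same change on two cores in this assay, a 5.3-fold lower number (0.73 log units; beyond the scatter) from compound 1 to compound 2 and a 7.0-fold lower number (0.85 log units; beyond the scatter) from compound 3 to compound 4, 1.3-fold (0.12 log units) apart, within the scatter of two such steps. This shows agreement between these two pairs only; it does not show that a methyl would lower the number at every place or on every core in this series, and it does not explain why the number falls.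

Methyl is the only group shown at the carbon between two ring nitrogen atoms, so it remains open whether an amine, a methoxy group or a longer chain such as ethyl would lower the number as far there. Going by these compounds, it also remains open whether the same methyl would bring a similar step on compound 2, which has a different group on its aniline ring.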